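A few compounds are considered here, and "the series" means these few. Any claim that something is new, unique, unknown or untested is made for them only; others in the source may bear on it.

Compound 1, `COc1ccc2c(c1)C(=O)[C@H](O)[C@@H](c1cccc(O)c1O)O2`, belongs to a small set of three close relatives tested in a functional assay on RAW264.7 cells (Rattus norvegicus) for inhibition, with RAW264.7 (Mus musculus) as the target, read by Griess assay, with stated times of 2 h and 16 h; on this read-out higher numbers stand for weaker inhibition and lower numbers for stronger inhibition. In this assay compound 1 gives > 100000 nM, which is a limit of the assay and not a measured number. Compound 2, `O=C1c2cc(O)ccc2O[C@H](c2cccc(O)c2O)[C@H]1O`, gives > 100000 nM, again only a limit. Compound 3, `COc1ccc2c(c1)C(=O)[C@@H](O)[C@H](c1cccc(O)c1O)O2`, gives > 100000 nM, also a limit. The step that the two limits leave unreadable from compound 1 to compound 2 and the step that the two limits leave unreadable from compound 1 to compound 3 therefore cannot be sized, because of the limit of > 100000 nM in this assay, at which 3 of the 3 values shown sit; compound 3 is the mirror image of compound 1, as the fact that compounds 1 and 3 differ only in the configuration as drawn shows, yet even that leaves no readable change.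

Compound 4, `COc1cc2c(cc1OC)C(=O)[C@H](O)[C@@H](c1cccc(O)c1O)O2`, differs from compound 1 by methoxy in place of hydrogen on an aromatic carbon. Going by the values given here, no measured step touches this part of the shared core, and no measured step has a readable size, so nothing here points to a change beyond the scatter in either direction. Compound 4 is expected to sit at the same limit, and the step that the limit leaves unreadable from compound 1 to compound 4 is estimated as essentially flat. Compound 4 is accordingly estimated at 150000 nM, within a range from 50000 nM to 500000 nM.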

Compound 4, half-maximal inhibitory concentration: 50300 nM
Compound 4: middle estimate off by 3.0-fold (0.47 log units), on the high side, within the range that was stated.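

Methoxy on this aromatic carbon, ortho to the methoxy group already present, gives the first value in this assay that is a measured number and not a limit: compound 4 gives 50300 nM. The change reads as an at least 1.9-fold lower number from compound 1 to compound 4 (0.29 log units; that floor lies within the scatter), so the true size may be larger, but what can be read does not rise clear of the usual scatter, and no real gain from this methoxy is established. This step can be read only as a floor, and the earlier steps cannot be read at all, for one reason: the limit of > 100000 nM in this assay, at which 3 of the 4 values shown sit.

As far as these compounds go, whether an amine or a carboxylic acid on this same aromatic carbon would give a clearly lower number stays open. Also open, from the compounds shown here alone, is whether this added methoxy would bring a measurable value on the mirror-image core of compound 3.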